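The compounds below may be only part of what the source reports. "The series", "measured", "known", "first", "only" and "open" are said of these compounds alone.

Measured compounds:
compound 1, `CCCCCCCCCCCCNC(=O)[C@@H](NS(=O)(=O)c1ccc(C)cc1)[C@@H](C)O`: 25600 nM
compound 2, `CCCCCCCCCCCCNC(=O)[C@@H](NS(=O)(=O)c1cccs1)[C@@H](C)O`: 27900 nM
compound 3, `CCCCCCCCCCCCCCCCCCNC(=O)[C@@H](NS(=O)(=O)c1ccc(C)cc1)[C@@H](C)O`: 32500 nM

In a functional assay on SW-620 cells (Homo sapiens) for cytotoxicity, read by MTT assay, with a stated time of 48 h (on this read-out higher numbers stand for weaker inhibition and lower numbers for stronger inhibition), the three measured compounds give numbers that all lie within the scatter of one another. From compound 1 to compound 2 the change is thiophen-2-yl in place of 4-methylphenyl on a sulfonyl sulfur, and the step is a 1.1-fold higher number from compound 1 to compound 2 (0.04 log units; within the scatter). The core of compound 3 differs from that of compound 1 by hexyl in place of hydrogen on a saturated chain carbon, ten or more bonds along the chain from an amide-type nitrogen, with the step of a 1.3-fold higher number from compound 1 to compound 3 (0.10 log units; within the scatter).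

Compound 4, `CCCCCCCCCCCCCCCCCCNC(=O)[C@@H](NS(=O)(=O)c1cccs1)[C@@H](C)O`, is not yet measured. It differs from compound 3 by thiophen-2-yl in place of 4-methylphenyl on a sulfonyl sulfur, the same change as from compound 1 to compound 2, made at the same place. Because the earlier step was a 1.1-fold higher number from compound 1 to compound 2 (0.04 log units; within the scatter), the account expects a similarly small step, estimated as a 1.0-fold higher number from compound 3 to compound 4 (0.02 log units; within the scatter). The estimate for compound 4 in this assay is 34000 nM, expected to fall between 17000 nM and 68000 nM.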

Compound 4, half-maximal inhibitory concentration: > 200000 nM
Compound 4 gave a limit, no number (the forecaster's own chance of this, stated with the estimate: 15%); at least 5.8-fold (0.76 log units) between middle value and limit.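

Placed on the core of compound 3, thiophen-2-yl in place of 4-methylphenyl gives an at least 6.1-fold higher number from compound 3 to compound 4 (0.78 log units; beyond the scatter), so the change does not carry over unaltered from the core of compound 1: the same change on two cores in this assay, a 1.1-fold higher number (0.04 log units; within the scatter) from compound 1 to compound 2 and an at least 6.1-fold higher number (0.78 log units; beyond the scatter) from compound 3 to compound 4, at least 5.6-fold (0.75 log units) apart, beyond the scatter of two such steps The hexyl change, read on the thiophen-2-yl compounds as an at least 7.1-fold higher number from compound 2 to compound 4 (0.85 log units; beyond the scatter), likewise differs from its earlier step: the same change on two cores in this assay, a 1.3-fold higher number (0.10 log units; within the scatter) from compound 1 to compound 3 and an at least 7.1-fold higher number (0.85 log units; beyond the scatter) from compound 2 to compound 4, at least 5.6-fold (0.75 log units) apart, beyond the scatter of two such steps Compound 4 gives > 200000 nM, a limit of the assay and not a number, so the full size of both steps remains unknown, and this single set of four compounds shows no general rule.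

The compounds shown leave open whether the two changes interact in the same way with another group on the sulfonyl sulfur, such as furan-2-yl. They also leave open where along the series of chains this shift appears, for example with a hexadecyl chain.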